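A few compounds are considered here, and "the series" means these few. Any claim that something is new, unique, unknown or untested is made for them only; others in the source may bear on it.

Measured in a functional assay on MGC-803 cells (Homo sapiens) for antiproliferative activity, read by MTT assay, with a stated time of 72 h (a lower number here means a stronger inhibitor, a higher number a weaker inhibitor), each value a limit and not a number:
- compound 1 `CCCSc1nc(N/N=C/c2ccc(Cl)cc2)c2nnn(Cc3ccccc3)c2n1`: > 64000 nM
- compound 2 `CCCSc1nc(N/N=C/c2cccc(Cl)c2)c2nnn(Cc3ccccc3)c2n1`: > 64000 nM
- compound 3 `CCCSc1nc(N/N=C/c2cccs2)c2nnn(Cc3ccccc3)c2n1`: > 64000 nM

Compound 3 gives only a limit, > 64000 nM. The whole record so far is the limit of > 64000 nM in this assay, at which 3 of the 3 values shown sit.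

The next analogue is compound 4 `CCCSc1nc(N/N=C/c2ccc(N(C)C)cc2)c2nnn(Cc3ccccc3)c2n1`, with the change (4-(dimethylamino)phenyl in place of thiophen-2-yl on a carbon with a double bond to nitrogen). The new group is 4-(dimethylamino)phenyl, in place of thiophen-2-yl on a carbon with a double bond to nitrogen.

Going by the values given here, three measured steps concern this same place: a step that the two limits leave unreadable from compound 1 to compound 2, a step that the two limits leave unreadable from compound 1 to compound 3 and a step that the two limits leave unreadable from compound 2 to compound 3. None of them has a readable size, so none gives a size or direction to carry over. With a step that the two limits leave unreadable from compound 2 to compound 3 as the closest guide, only weak activity is expected in this assay, and another result reported only as a limit is the likeliest outcome.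

The expected change is an at least 1.2-fold lower number from compound 3 to compound 4 (0.10 log units; that floor lies within the scatter). For compound 4 the estimate is 50000 nM, with an expected range of 12000 nM to 100000 nM.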

Compound 4, half-maximal inhibitory concentration: 13100 nM
Compound 4: the middle estimate sits 3.8-fold (0.58 log units) above what was measured, and the stated range covers the measured number.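

In this assay, compound 4 alone among the four analogues gives a number, which makes the substituent on the carbon with a double bond to nitrogen a place where a change can move the read-out away from the limit that the others share: the limit of > 64000 nM in this assay, at which 3 of the 4 values shown sit. The change to 4-(dimethylamino)phenyl gives an at least 4.8-fold lower number from compound 3 to compound 4 (0.68 log units; beyond the scatter), and the comparisons with the two chlorophenyl analogues give an at least 4.8-fold lower number from compound 2 to compound 4 (0.68 log units; beyond the scatter) and an at least 4.8-fold lower number from compound 1 to compound 4 (0.68 log units; beyond the scatter). All three steps start from a limit, so each is only a floor, and the steps among compound 1, compound 2 and compound 3 cannot be read.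

On these data alone, whether a primary amine, a methoxy group or a morpholine in place of dimethylamino would keep this activity remains open. Also open, as far as these compounds go, is whether a longer chain in place of the propyl chain on sulfur would shift the value of compound 4.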